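Halogen for methoxy on the aryl ring of the shared core

This account rests on a few compounds, and the source may have more. Where it says the series, first, only, none or still open, it means among the compounds named here.

Three compounds of this series have numbers in a functional assay on HepG2 cells (Homo sapiens) for inhibition, read by CCK-8 assay, with a stated time of 48 h; a lower number here means a stronger inhibitor, a higher number a weaker inhibitor. Compound 1 `O=C1CSC(N2N=C(c3ccc(Br)cc3)CC2c2ccc3ccccc3c2)=N1` gives 18200 nM. Compound 2 `COc1ccc(C2=NN(C3=NC(=O)CS3)C(c3cccc4ccccc34)C2)cc1` gives 7850 nM, and compound 3 `Cc1ccc(C2=NN(C3=NC(c4ccccc4)CS3)C(c3ccc4ccccc4c3)C2)cc1C` gives 7370 nM. Compound 2 therefore holds the second highest number of the three: its nearest neighbour is compound 3, whose number lies within the scatter of it, while compound 1 sits furthest away with a number beyond the scatter above it. For the measured compounds named here, no single-point step between two measured compounds is available, so the change considered here is read only against those three numbers.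

Compound 4 `O=C1CSC(N2N=C(c3ccc(Cl)cc3)CC2c2cccc3ccccc23)=N1` has not yet been measured in this assay. Against compound 2 it differs in one place: chloro in place of methoxy on an aromatic carbon. Going by the values given here, the change is a halogen entering where a methoxy stood, and the only measured halogen-bearing member, compound 1, returned the highest number, at 18200 nM, though it also differs elsewhere.

For compound 4 the expectation is a modest rise in number, leaning toward compound 1 but short of it, with no strong claim beyond the scatter. The step expected is a 1.4-fold higher number from compound 2 to compound 4 (0.15 log units; within the scatter). Compound 4 is thus estimated at 11000 nM, within a range of 5000 nM to 25000 nM.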

Compound 4, half-maximal inhibitory concentration: 16500 nM
Compound 4: middle estimate off by 1.5-fold (0.18 log units), on the low side; the measured number falls inside the stated range.
By their numbers in this assay, from the lowest: compounds 3 and 2 (each within the scatter of the next); then compounds 4 and 1 (each within the scatter of the next).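

In this assay, for the compounds shown here, replacing 4-methoxyphenyl with 4-chlorophenyl gives a 2.1-fold higher number from compound 2 to compound 4 (0.32 log units; beyond the scatter) and supplies the first step that isolates a single place. The step is modest but lies beyond the scatter, so at this position, para to a large group, the swap from methoxy to chloro is not neutral for the number, with the rest of the structure held constant. Until now, the halogen-bearing compound 1 differed from the other measured compounds in more than one place, so no shift could be tied to this change alone; nothing measured here accounts for the direction of the step.

This is one pair, so it does not show whether the step belongs to chloro specifically or would also appear with fluoro, a dimethylamino group or a carboxylic acid at the same position. It also leaves open whether the same exchange would move the number in the same direction and by a similar size on the cores of compound 1 and compound 3.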